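The compounds below may be only part of what the source reports. "The series", "measured", "known", "first", "only" and "open" are said of these compounds alone.

Compound 2 `COc1cccc(-c2cncc(O[C@@H]3CCNC3)c2)c1` gives 1120 nM in an assay on a protein complex for binding affinity to Neuronal acetylcholine receptor; alpha4/beta2 (Rattus norvegicus) (on this read-out lower numbers stand for stronger inhibition and higher numbers for weaker inhibition), the second highest of the three numbers. Compound 1 `c1ccc(-c2cncc(O[C@@H]3CCNC3)c2)cc1` gives 1820 nM in this assay, and compound 3 `COc1cccc(-c2cc(O[C@@H]3CCNC3)cnc2Cl)c1` gives 58 nM. Compound 4 `Clc1cccc(-c2cncc(O[C@@H]3CCNC3)c2)c1` has not been measured; it differs from compound 2 by chloro in place of methoxy on an aromatic carbon. Among the compounds with values here, two measured steps bear on this, though neither matches it directly: one gave a 1.6-fold lower number from compound 1 to compound 2 (0.21 log units; within the scatter), the other gave a 19-fold lower number from compound 2 to compound 3 (1.29 log units; beyond the scatter). Because the methoxy entering in a 1.6-fold lower number from compound 1 to compound 2 (0.21 log units; within the scatter) barely moved the number, and because the chloro in a 19-fold lower number from compound 2 to compound 3 (1.29 log units; beyond the scatter) sat on the other ring, no step beyond the scatter is anticipated. Compound 4 is therefore expected to give 1000 nM, within a range of 400 nM to 2500 nM. For compound 4 this amounts to an expected 1.1-fold lower number from compound 2 to compound 4 (0.05 log units; within the scatter).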

Compound 4, half-maximal inhibitory concentration: 940 nM
Compound 4: middle estimate off by 1.1-fold (0.03 log units), on the high side, within the range that was stated.
By their numbers in this assay, from the lowest: compound 3; then compounds 4, 2 and 1 (each within the scatter of the next).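

In this assay, at this place on the six-membered aromatic ring of carbon only, meta to a large group, chloro in place of methoxy gives a 1.2-fold lower number from compound 2 to compound 4 (0.08 log units; within the scatter), and chloro in place of hydrogen gives a 1.9-fold lower number from compound 1 to compound 4 (0.29 log units; within the scatter). Hydrogen, methoxy and chloro are therefore not told apart at this position. The same chloro change differs sharply between the two places it occupies: the same change on two cores in this assay, a 19-fold lower number (1.29 log units; beyond the scatter) from compound 2 to compound 3 and a 1.9-fold lower number (0.29 log units; within the scatter) from compound 1 to compound 4, 10-fold (1.00 log units) apart, beyond the scatter of two such steps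

The compounds shown leave open whether an amine, a carboxylic acid or a longer chain at this position would move the number beyond the scatter. They also leave open whether the chloro of compound 3 needs the methoxy.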